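The source may report more compounds than this note shows. Statements on the series, on what has been measured and on what is new or still open speak of the compounds shown alone.

Three compounds share one core. Compound 1 `Brc1cn2ccnc2c(-c2ccc3ncn(C4CCCCC4)c3c2)n1` carries a bromo group; in a functional assay on T47D cells (Homo sapiens) for inhibition, read by sulforhodamine B assay, with a stated time of 48 h, tested at 10 uM (a higher number here means more inhibition at the concentration tested (going by the name of the read-out), a lower number less inhibition), compound 1 gives 49.7%. Compound 2 `Fc1ccc(-c2cn3ccnc3c(-c3ccc4ncn(C5CCCCC5)c4c3)n2)cc1` carries a 4-fluorophenyl group instead, and in this assay compound 2 gives 33.3%; the step of a number 16.4 percentage points lower from compound 1 to compound 2 (beyond the scatter). Compound 3 `CCc1ccc(-c2cn3ccnc3c(-c3ccc4ncn(Cc5ccccc5)c4c3)n2)cc1` carries a 4-ethylphenyl group and a benzyl group on the core, and in this assay compound 3 gives 94.8%, the highest of the three numbers, beyond the scatter above both compound 1 and compound 2.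

Compound 4 `c1ccc(Cn2cnc3ccc(-c4nc(-c5cccc6ccccc56)cn5ccnc45)cc32)cc1` differs from compound 3 in one place: naphthalen-1-yl in place of 4-ethylphenyl on an aromatic carbon. Going by the values given here, no measured step exchanges one aromatic ring for another at this position; the only measured step, from bromo to 4-fluorophenyl, is of a different kind and was modest. Since compound 3 already sits high and the change keeps a carbon-only aromatic group there, the expectation is a step of a number 22.8 percentage points lower from compound 3 to compound 4 (beyond the scatter), with wide uncertainty. In this assay compound 4 is expected to give 72%, estimated between 35% and 96%.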

Compound 4, a percentage reported as inhibition, at one concentration (the size of the read-out at that concentration, not a potency): 73.8%
For compound 4 the middle estimate is 1.8 percentage points below the measured one, within the range that was stated.
By their numbers in this assay, from the lowest: compound 2; then compound 1; then compound 4; then compound 3.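

Within the series shown, this is the first measured exchange of one carbon-only aromatic group for another at this position: in this assay, replacing 4-ethylphenyl with naphthalen-1-yl gives a number 21 percentage points lower from compound 3 to compound 4 (beyond the scatter). The larger group with two aromatic rings therefore lowers the number, yet compound 4 still gives 73.8%, so this position can carry naphthalen-1-yl without losing the inhibition altogether. No measurement here explains why the number falls.

This single pair cannot separate the effect of removing the ethyl group from that of adding the second ring, and a plain phenyl or naphthalen-2-yl group would help to tell those apart. From the compounds shown here alone, how an amine or a carboxylic acid on the phenyl ring would fare at this position also remains open.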